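A few compounds are considered here, and "the series" means these few. Any claim that something is new, unique, unknown or untested is made for them only; others in the source may bear on it.

Measured in a functional assay on HCC827 cells (Homo sapiens) for antiproliferative activity, read by MTT assay, with a stated time of 72 h; a higher number here means a weaker inhibitor, a lower number a stronger inhibitor:
compound 1 `CN1CCN(c2ccc(Nc3ncc4nc([S+]([O-])c5ccccc5)n(CC5CC5)c4n3)cc2)CC1`: 838 nM
compound 2 `CN1CCN(c2ccc(Nc3ncc4nc([S+]([O-])c5ccccc5)n(C5CCCC5)c4n3)cc2)CC1`: 64.7 nM

Compound 1 holds the higher of the two numbers. Compound 3 `CN1CCN(c2ccc(Nc3ncc4nc(Sc5ccccc5)n(CC5CC5)c4n3)cc2)CC1` departs from it at one place: a group of 7 heavy atoms (6 carbon, 1 sulfur; one six-membered aromatic ring of carbon only) in place of a group of 8 heavy atoms (6 carbon, 1 oxygen, 1 sulfur; one six-membered aromatic ring of carbon only), on an aromatic carbon. For the measured compounds named here, the only measured step is a 13-fold lower number from compound 1 to compound 2 (1.11 log units; beyond the scatter). That large step concerns cyclopentyl in place of cyclopropylmethyl on an aromatic nitrogen, so it does not bear directly on the change at the aromatic carbon. Going by the values given here, no measured compound shows what phenylsulfanyl does there. With nothing to set a direction, the estimated change is a 1.2-fold lower number from compound 1 to compound 3 (0.08 log units; within the scatter), and none is expected beyond the scatter. For compound 3 the expected value is 700 nM, with an estimated range of 180 nM to 2700 nM.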

Compound 3, half-maximal inhibitory concentration: 660 nM
Compound 3: middle estimate off by 1.1-fold (0.03 log units), on the high side; low and high end bracket the measured number.
By their numbers in this assay, from the lowest: compound 2; then compounds 3 and 1 (each within the scatter of the next).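

In this assay, for the compounds shown here, putting phenylsulfanyl on this aromatic carbon, with cyclopropylmethyl kept on the ring nitrogen, gave a 1.3-fold lower number from compound 1 to compound 3 (0.10 log units; within the scatter), the first reading of this position. Taking out the oxygen therefore left the number within the scatter in this setting, and the change on the aromatic nitrogen remains the only step beyond it. Nothing available offers an explanation for this result.

The compounds shown leave open whether phenylsulfanyl would behave alike with cyclopentyl on the aromatic nitrogen. They also leave open what an amine or a carboxylic acid would do on this aromatic carbon.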